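The source may hold more compounds than are shown below. What is called first, only, known or untested is meant among the compounds shown, and "the series" means these compounds.

Measured in a physicochemical assay for solubility, read by LC-MS, in phosphate buffer, with a stated time of 24 h, at pH 7.4; on this read-out higher numbers stand for higher solubility and lower numbers for lower solubility:
- compound 1 `Cn1cc(-c2cnc(NCc3c(F)ccc4c3CCO4)c3cn[nH]c(=O)c23)cn1` gives 1000 nM
- compound 2 `CNC(=O)c1ccc(-c2cnc(NCc3c(F)ccc4c3CCO4)c3cn[nH]c(=O)c23)c(C)n1` gives 19000 nM
- compound 3 `CN(c1ccn(C)n1)c1cnc(NCc2c(F)ccc3c2CCO3)c2cn[nH]c(=O)c12` gives 12000 nM

Compound 3 sits well clear of compound 1 and within the scatter of compound 2, as a 1.6-fold lower number from compound 2 to compound 3 (0.20 log units; within the scatter) shows. Within the data shown here, compound 4 `Cc1nn(C)cc1-c1cnc(NCc2c(F)ccc3c2CCO3)c2cn[nH]c(=O)c12` carries 1,3-dimethyl-1H-pyrazol-4-yl in place of methyl(1-methyl-1H-pyrazol-3-yl)amino on an aromatic carbon as its only change. Compound 1 carries 1-methyl-1H-pyrazol-4-yl at that place, which makes a 12-fold higher number from compound 1 to compound 3 (1.08 log units; beyond the scatter) the most relevant measured step, read in reverse. A different group at that place gave a 19-fold higher number from compound 1 to compound 2 (1.28 log units; beyond the scatter) as well. Among the measured compounds shown here, no measured step isolates the added methyl, so only part of the reverse step is expected. The estimated change is a 4.0-fold lower number from compound 3 to compound 4 (0.60 log units; beyond the scatter) in this measurement. For compound 4 the expected value is 3000 nM, within an estimated range of 800 nM to 11000 nM.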

Compound 4, solubility: 9000 nM
Compound 4: the middle estimate sits 3.0-fold (0.48 log units) below what was measured, within the range that was stated.
By their numbers in this assay, from the lowest: compound 1; then compounds 4, 3 and 2 (each within the scatter of the next, the first and the last beyond it).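

In this assay, adding only a methyl to the pyrazole gives a 9.0-fold higher number from compound 1 to compound 4 (0.95 log units; beyond the scatter), so even this very small change at this position moves the number far beyond the scatter. The methyl(1-methyl-1H-pyrazol-3-yl)amino and 1,3-dimethyl-1H-pyrazol-4-yl groups cannot be told apart, at a 1.3-fold lower number from compound 3 to compound 4 (0.12 log units; within the scatter), whereas replacing 2-methyl-6-(methylcarbamoyl)pyridin-3-yl gives a 2.1-fold lower number from compound 2 to compound 4 (0.32 log units; beyond the scatter). Nothing available explains these differences. On these data alone, whether an ethyl in place of this methyl would give a similar number remains open. So does the outcome with a morpholine at this position.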